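Piperidine in Place of Morpholine on a Thiocarbonyl Carbon

The compounds below may be only part of what the source reports. "The series", "measured", "known", "first", "only" and "open" are said of these compounds alone.

Of the compounds shown here, two have so far been tested in a functional assay on A-375 cells (Homo sapiens) for cytotoxicity, read by MTT assay, with a stated time of 72 h, tested at 30 uM; on this read-out higher numbers stand for more inhibition of growth at the one concentration tested and lower numbers for less inhibition of growth. Compound 1 `N/C(=N\NC(=S)N1CCCCC1)c1ccccn1` gives 87%, and compound 2 `Cc1cccc(/C(N)=N/NC(=S)N2CCOCC2)n1` gives 74.3%. Compound 2 therefore stands as the lower of the two numbers, and its gap to compound 1 lies beyond the usual scatter. These two structures differ in more than one place, so their values alone do not show which change carries the difference. Compound 3 `Cc1cccc(/C(N)=N/NC(=S)N2CCCCC2)n1` is not yet measured. It differs from compound 2 by piperidin-1-yl in place of morpholin-4-yl on a thiocarbonyl carbon. Compound 3 thus carries the same piperidin-1-yl group on its thiocarbonyl carbon as compound 1, and in this assay compound 1 gives 87%. The expected step of a number 7.7 percentage points higher from compound 2 to compound 3 (within the scatter) is upward, of a size close to the edge of the scatter. Compound 3 is estimated at 82%, within a range from 66% to 95%.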

Compound 3, percent growth inhibition at one concentration: 80.9%
For compound 3 the middle estimate is 1.1 percentage points above the measured one; the range from low to high includes it.
By their numbers in this assay, from the lowest: compounds 2, 3 and 1 (each within the scatter of the next, the first and the last beyond it).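

Compound 3 links the two earlier compounds, so each of the two changes between them can now be read alone. In this assay piperidin-1-yl in place of morpholin-4-yl on a thiocarbonyl carbon gives a number 6.6 percentage points higher from compound 2 to compound 3 (within the scatter) and so cannot be told apart from repeat-to-repeat variation. Methyl in place of hydrogen on an aromatic carbon gives a number 6.1 percentage points lower from compound 1 to compound 3 (within the scatter) and likewise stays inside that variation, so the gap beyond the scatter between compound 1 and compound 2 appears only with both changes taken together.

Still open, from the compounds shown here alone, is how an open-chain dimethylamino group or a piperazine ring on the thiocarbonyl carbon, or an ethyl group on the aromatic carbon, would read out. Nothing available bears on the reason for these numbers.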